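Series notes: from an oxane-bearing chain to a methylphenyl one

The source may report more compounds than this note shows. Statements on the series, on what has been measured and on what is new or still open speak of the compounds shown alone.

Of the compounds shown here, three have been measured in a physicochemical assay for lipophilicity, at pH 7.4; a higher number here means a more lipophilic compound, a lower number a more polar compound. Compound 1 `CNC(=O)c1cc(C(=O)NC2CC2)cn(CC2CCCOC2)c1=O` gives 2. Compound 2 `CNC(=O)c1cc(C(=O)NC2CC2)cn(Cc2cccc3[nH]c(C)nc23)c1=O` gives 1.5, and compound 3 `CNC(=O)c1cc(C(=O)NC2CCOCC2)cn(Cc2ccccc2)c1=O` gives 2.8. Within these three numbers compound 1 stands second highest: compound 2 sits below it by a gap beyond the scatter, and compound 3 sits above it by a larger gap, also beyond the scatter. Going by the values given here, no two of the measured compounds differ in one place only, so no single step has been read directly.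

Compound 4 `CNC(=O)c1cc(C(=O)NC2CC2)cn(Cc2cccc(C)c2)c1=O` has not yet been measured in this assay. Against compound 1 the change is 3-methylphenyl in place of oxan-3-yl on a saturated chain carbon bound to an aromatic nitrogen. A six-membered non-aromatic ring with one hetero atom and one hydrogen-bond acceptor leaves, and a six-membered aromatic ring of carbon only with no acceptor enters.

On the numbers shown, an increase beyond the scatter is expected, because compound 3 with its value 2.8 is the highest of the three and no measured compound points the other way. The step from compound 1 to compound 4 is estimated at a number 1.40 log units higher from compound 1 to compound 4 (beyond the scatter). Compound 4 is therefore expected at about 3.4, with a range from 2.9 to 3.9.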

Compound 4, distribution coefficient: 3.6
Estimate against measurement, compound 4: 0.20 log units below; the measured number falls inside the stated range.
By their numbers in this assay, from the lowest: compound 2; then compound 1; then compound 3; then compound 4.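

The position on a saturated chain carbon bound to an aromatic nitrogen now has its first directly read step: in this assay, 3-methylphenyl in place of oxan-3-yl gives a number 1.60 log units higher from compound 1 to compound 4 (beyond the scatter), a large step on an otherwise unchanged core. Compounds 2 and 3 each differ from compound 1 and compound 4 in more than one place or by no listed step, so their steps cannot be read, and this single exchange is the only one that isolates the position. The exchange bundles several differences, since a non-aromatic ring with one hetero atom and one hydrogen-bond acceptor leaves while an aromatic ring of carbon only, with no acceptor and one more heavy atom, enters, and no measurement at hand bears on the cause of the step.

How the step divides among these differences stays open: cyclohexyl at this place would keep a non-aromatic ring without the ring oxygen, and plain phenyl on the same cyclopropyl amide would show what the methyl contributes. Whether the position also tolerates a charged group, such as an amine or a carboxylic acid on the ring, remains equally unsettled.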